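The source may hold more compounds than are shown below. What is called first, only, known or untested is meant among the compounds shown, and "the series" means these compounds.

Of the compounds shown here, three built on a shared core have been tested in a functional assay on HepG2 cells (Homo sapiens) for antiproliferative activity, read by MTT assay, with a stated time of 48 h; a higher number here means a weaker inhibitor, a lower number a stronger inhibitor. Compound 1 `O=[N+]([O-])c1cc(C(F)(F)F)cc([N+](=O)[O-])c1Oc1ccccc1/C=N\OCc1ccccc1` gives 1330 nM, compound 2 `O=[N+]([O-])c1cc(C(F)(F)F)cc([N+](=O)[O-])c1Oc1ccc(Cl)cc1/C=N\OCc1ccccc1` gives 1790 nM, and compound 3 `O=[N+]([O-])c1cc(C(F)(F)F)cc([N+](=O)[O-])c1Oc1c(Cl)cc(Cl)cc1/C=N\OCc1ccccc1` gives 1120 nM. Compound 3 therefore stands within the scatter of both other compounds, and the three values cannot be ranked. The next compound to be measured is compound 4 `O=[N+]([O-])c1cc(C(F)(F)F)cc([N+](=O)[O-])c1Oc1c(Cl)cc(Cl)cc1/C=N/OCc1ccc(Cl)cc1Cl`. Its structure departs from that of compound 3 by a group of 12 heavy atoms (8 carbon, 1 nitrogen, 1 oxygen, 2 chlorine; one six-membered aromatic ring of carbon only) in place of a group of 10 heavy atoms (8 carbon, 1 nitrogen, 1 oxygen; one six-membered aromatic ring of carbon only), on an aromatic carbon, on an aromatic carbon of a six-membered aromatic ring of carbon only, ortho to a large group and meta to two chloro groups.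

The closest evidence comes from two measured replacements of hydrogen by chloro on an aromatic carbon: a 1.3-fold higher number from compound 1 to compound 2 (0.13 log units; within the scatter), and a 1.6-fold lower number from compound 2 to compound 3 (0.20 log units; within the scatter). Neither step goes beyond the scatter. Both were made elsewhere in the molecule, not in the group exchanged here, so they offer only indirect guidance. For the measured compounds named here, no compound tested so far carries chloro in that group. On this evidence, no shift beyond the scatter is expected in this assay, and no direction can be favoured. The expected change is a 1.0-fold lower number from compound 3 to compound 4 (0.01 log units; within the scatter). For compound 4 the estimated value is 1100 nM, with an expected range from 400 nM to 3000 nM.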

Compound 4, half-maximal inhibitory concentration: 940 nM
Estimate against measurement, compound 4: 1.2-fold (0.07 log units) above, within the range that was stated.
By their numbers in this assay, from the lowest: compounds 4, 3, 1 and 2 (each within the scatter of the next).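

In this assay the group of 12 heavy atoms in place of the group of 10 heavy atoms gives a 1.2-fold lower number from compound 3 to compound 4 (0.08 log units; within the scatter). This shows that two chloro groups on the six-membered aromatic ring of the exchanged group, a part of the molecule where none of the other three compounds carries chloro, go with no shift that can be told from the scatter, although the two structures are also drawn with opposite geometry at the double bond outside the aromatic rings, so that this one step covers both differences at once. No measurement at hand accounts for this result.

The compounds shown leave open whether the chloro groups and the change of geometry would each stay within the scatter alone, or whether two separate shifts offset each other in this pair. They also leave open how this assay would respond to a methoxy group, an amine or a carboxylic acid on that ring in place of chloro.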